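Para- and meta-halogenated benzamides on a shared core: toxicity notes

The source may report more compounds than this note shows. Statements on the series, on what has been measured and on what is new or still open speak of the compounds shown alone.

Compound 1 `Cn1c(-c2ccccc2)cnc1NC(=O)c1ccc(Cl)cc1`, compound 2 `Cn1c(-c2ccccc2)cnc1NC(=O)c1ccc(Br)cc1` and compound 3 `Cn1c(-c2ccccc2)cnc1NC(=O)c1cccc(Br)c1` share one core and differ only in the halogenated benzamide. In a toxicity assay on THP-1 cells (Homo sapiens) for inhibition (a lower number here means that less compound is tolerated, a higher number that more compound is tolerated), compound 1 gives > 100000 nM, which is a limit of the assay, not a number. In this assay compound 2 gives > 100000 nM, again a limit. In this assay compound 3 gives > 50000 nM, also a limit. The change from compound 2 to compound 1 is chloro in place of bromo on an aromatic carbon and its step in this assay is a step that the two limits leave unreadable from compound 2 to compound 1, unreadable because the limit of > 100000 nM in this assay, at which 2 of the 3 values shown sit, caps both values. The cores of compound 2 and compound 3 differ by 3-bromophenyl in place of 4-bromophenyl on a carbonyl carbon. Compound 4 `Cn1c(-c2ccccc2)cnc1NC(=O)c1cccc(Cl)c1` is not yet measured; it arises from compound 3 by chloro in place of bromo on an aromatic carbon, the same kind of change as from compound 2 to compound 1, though here the place is meta to a large group rather than para to a large group. Compound 4 is expected to give a step that the limit leaves unreadable from compound 3 to compound 4 in this assay, resting on compound 3 at > 50000 nM and on the limit of > 50000 nM in this assay, at which 1 of the 3 values shown sits, together with the limit of > 100000 nM in this assay, at which 2 of the 3 values shown sit, all limits with no toxicity read. The estimate for compound 4 in this assay is 100000 nM, between 50000 nM and 200000 nM.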

Compound 4, half-maximal cytotoxic concentration: > 50000 nM
Compound 4 ended at the assay's limit (the forecaster's own chance of this, stated with the estimate: 80%); the middle value is on the limit's open side.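

In this assay compound 4 gives > 50000 nM, which is a limit and not a number. Its steps to compound 1, compound 2 and compound 3 cannot be read, because all of these values are limits: the limit of > 50000 nM in this assay, at which 2 of the 4 values shown sit.

The compounds shown leave open where toxicity begins for any of the four halogenated benzamides, and whether the identity or place of the halogen changes it at all.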